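Methylsulfonyl in place of fluoro: compound 2 to compound 4

A few compounds are considered here, and "the series" means these few. Any claim that something is new, unique, unknown or untested is made for them only; others in the source may bear on it.

Measured so far:
compound 1 `C[C@H](Nc1ncnc2[nH]cnc12)c1nn(-c2cccnc2)c2ccc(F)cc12`: 13%
compound 2 `C[C@H](Nc1ncnc2[nH]cnc12)c1nn(-c2cccc(F)c2)c2cc(F)ccc12`: 28%
compound 3 `C[C@H](Nc1nc(N)nc(N)c1C#N)c1nn(-c2cccc(S(C)(=O)=O)c2)c2cc(Cl)ccc12`: 72%

All three numbers come from a functional assay on Hep 3B2 cells (Homo sapiens) for inhibition, read by sulforhodamine B assay, with a stated time of 72 h, tested at 10 uM; on this read-out higher numbers stand for more inhibition at the one concentration tested (going by the name of the read-out) and lower numbers for less inhibition. Compound 2 gives 28%, the second highest of the three. Its nearest neighbour in value is compound 1, which gives 13%, a gap beyond the usual scatter; the furthest is compound 3, which gives 72%, also beyond the scatter. No pair of these compounds differs in only one place, so no single-point step can be read off, and the spread is set by compounds that differ both in the shared core and in the aryl substituents.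

Compound 4 `C[C@H](Nc1ncnc2[nH]cnc12)c1nn(-c2cccc(S(C)(=O)=O)c2)c2cc(F)ccc12` keeps the core of compound 2 and changes one group:

methylsulfonyl in place of fluoro on an aromatic carbon

Cut one bond further out, 3-fluorophenyl becomes 3-(methylsulfonyl)phenyl. The same methylsulfonyl group is present in compound 3, which gives 72%, though on a different core and with chloro rather than fluoro, so that value is only a loose pointer. The step from compound 2 to compound 4 is expected to be upward and beyond the scatter, a number 17 percentage points higher from compound 2 to compound 4 (beyond the scatter). Compound 4 is estimated at 45%, with a range from 25% to 65%.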

Compound 4, a percentage reported as inhibition, at one concentration (the size of the read-out at that concentration, not a potency): 11%
Compound 4: middle estimate off by 34 percentage points, on the high side; measured number below the stated range.
By their numbers in this assay, from the lowest: compounds 4 and 1 (each within the scatter of the next); then compound 2; then compound 3.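

Exchanging fluoro for methylsulfonyl on this aromatic carbon gives, in this assay, a number 17 percentage points lower from compound 2 to compound 4 (beyond the scatter), the first single-change step available in the series. On this core, then, methylsulfonyl at this position goes with less inhibition at the one concentration tested than fluoro, so the group does not by itself raise the read-out here. Nothing at hand accounts for this drop.

Going by these compounds, whether an amine, a carboxylic acid or a methoxy group on this carbon would read closer to compound 2 or to compound 4 remains open. Also open, on these data alone, is whether the exchange of fluoro for methylsulfonyl runs in the same direction on the core of compound 3, since this single pair speaks for one core only.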